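Sulfonyl substituent change at the aryl sulfonyl of compound 1

The compounds below may be only part of what the source reports. "The series", "measured", "known", "first", "only" and "open" are said of these compounds alone.

Compound 1 `CCC(CC)S(=O)(=O)c1ccc(S(=O)(=O)N2CCC[C@@H](C(=O)N3CCC(F)(F)CC3)C2)cc1` gives 13 nM in a functional assay on MIA PaCa-2 cells (Homo sapiens) for inhibition, read by MTT assay, with a stated time of 7 days (on this read-out higher numbers stand for weaker inhibition and lower numbers for stronger inhibition), the lowest number of the three measured and therefore the strongest inhibitor of this set. Compound 2 `CCN(CC)S(=O)(=O)c1ccc(S(=O)(=O)N2CCC[C@@H](C(=O)N3CCC(C(F)(F)F)CC3)C2)cc1` gives 320 nM and compound 3 `CCN(CC)S(=O)(=O)c1ccc(S(=O)(=O)N2CCC[C@@H](C(=O)N[C@@H]3CCOC3)C2)cc1` gives 750 nM; both gaps to compound 1 lie beyond the scatter. For the measured compounds named here, the only single-point step recorded, a 2.3-fold higher number from compound 2 to compound 3 (0.37 log units; beyond the scatter), concerns the amide end and is modest.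

Compound 4 `CC(C)NS(=O)(=O)c1ccc(S(=O)(=O)N2CCC[C@@H](C(=O)N3CCC(F)(F)CC3)C2)cc1` differs from compound 1 at the other end: isopropylamino in place of pentan-3-yl on a sulfonyl sulfur; cut one bond further out, (pentan-3-yl)sulfonyl becomes isopropylsulfamoyl. Going by the values given here, no measured pair isolates a change on the sulfonyl sulfur. Compounds 2 and 3, which carry a nitrogen on that sulfur, both give higher numbers than compound 1, but each also differs at the amide, so the sulfonyl contribution cannot be separated. A moderately higher number for compound 4 is therefore expected, with wide uncertainty: the estimated step is a 4.6-fold higher number from compound 1 to compound 4 (0.66 log units; beyond the scatter). Compound 4 is estimated at 60 nM, within 15 nM to 250 nM.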

Compound 4, half-maximal inhibitory concentration: 350 nM
The estimate for compound 4 lay 5.8-fold (0.77 log units) below the measured number; measured number outside the range, above it.
By their numbers in this assay, from the lowest: compound 1; then compounds 2 and 4 (each within the scatter of the next); then compound 3.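

In this assay, isopropylamino in place of pentan-3-yl on a sulfonyl sulfur gives a 27-fold higher number from compound 1 to compound 4 (1.43 log units; beyond the scatter), with the rest of the molecule unchanged. For the compounds shown here, this is the first measured pair to isolate this position, and its step is larger than the one recorded at the amide end, a 2.3-fold higher number from compound 2 to compound 3 (0.37 log units; beyond the scatter), so the sulfonyl substituent can by itself move the number substantially. No measurement on hand explains the size of this step.

The pair does not separate the entry of the nitrogen, with its hydrogen-bond donor, from the change of carbon chain. Methyl(isopropyl)amino, which has no amine hydrogen, and cyclopentyl, which has no nitrogen, on the same sulfonyl sulfur would each address one side of that question.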